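Half-life of a Carboxylic Acid Series in Guinea Pig

A few compounds are considered here, and "the series" means these few. Any claim that something is new, unique, unknown or untested is made for them only; others in the source may bear on it.

Of the compounds shown here, three built on a shared core have been measured in an in vivo ADME assay on the whole organism (Cavia porcellus); on this read-out lower numbers stand for a shorter-lived compound and higher numbers for a longer-lived compound. Compound 1 `CC(C)(C(=O)N1CCC(CC(=O)O)CC1)C(NC(=O)c1ccc(C(=N)N)cc1)c1ccc(Cl)cc1` gives 1.2 h. Compound 2 `CC(C)(C(=O)N1CCC(CC(=O)O)CC1)C(NC(=O)c1ccc(C(=N)N)cc1)c1ccc(O)cc1` gives 1.05 h. Compound 3 `CC(C)(C(=O)N1CCC(CC(=O)O)CC1)C(NC(=O)c1ccc(C(=N)N)cc1)c1cccc(Cl)c1` gives 2.5 h, the highest of the three numbers. Compound 1 and compound 3 have the same atoms joined differently: 3-chlorophenyl in place of 4-chlorophenyl on a saturated chain carbon bound to an amide-type nitrogen and a saturated chain carbon. That change made the step of a 2.1-fold higher number from compound 1 to compound 3 (0.32 log units; beyond the scatter), and compound 2 and compound 3 stand apart by a 2.4-fold higher number from compound 2 to compound 3 (0.38 log units; beyond the scatter).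

Compound 4 `CC(C)(C(=O)N1CCC(CC(=O)O)CC1)C(NC(=O)c1ccc(C(=N)N)cc1)c1cccc(O)c1` has not yet been measured in this assay. It differs from compound 3 by hydroxy in place of chloro on an aromatic carbon. The same kind of change runs from compound 1 to compound 2, namely (hydroxy in place of chloro on an aromatic carbon); what differs around the place is that in compound 2 the hydroxy sits para to a large group, whereas in compound 4 it sits meta to a large group. In this assay the first of these changes made the step of a 1.1-fold lower number from compound 1 to compound 2 (0.06 log units; within the scatter), which stays within the scatter.

Because the step of a 1.1-fold lower number from compound 1 to compound 2 (0.06 log units; within the scatter) was so small, compound 4 is expected to stay close to compound 3, with an estimated step of a 1.1-fold lower number from compound 3 to compound 4 (0.06 log units; within the scatter). The estimate for compound 4 in this assay is 2.2 h, expected to fall between 1.2 h and 4 h. The different place around the change, known only from this one pair, leaves room for a larger shift.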

Compound 4, half-life: 1.08 h
Estimate against measurement, compound 4: 2.0-fold (0.31 log units) above; measured number below the stated range.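

In this assay, hydroxy in place of chloro now gives a 2.3-fold lower number from compound 3 to compound 4 (0.36 log units; beyond the scatter). Taken alone, this step lies beyond the scatter while the earlier one does not, yet the gap between the two does not, so the two steps cannot be told apart: the same change on two cores in this assay, a 1.1-fold lower number (0.06 log units; within the scatter) from compound 1 to compound 2 and a 2.3-fold lower number (0.36 log units; beyond the scatter) from compound 3 to compound 4, 2.0-fold (0.31 log units) apart, within the scatter of two such steps

Among the compounds shown here, this does not show that the change behaves differently on the two cores, and with only two pairs it does not prove that it behaves the same either. Compound 4 sits with the other compounds, showing a 1.0-fold higher number from compound 2 to compound 4 (0.01 log units; within the scatter) and a 1.1-fold lower number from compound 1 to compound 4 (0.05 log units; within the scatter), both within the scatter, so compound 3 alone stands apart among the four, and compound 1, which also carries a chloro, goes against any simple rule that chloro gives the longer half-life.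

The compounds shown leave open whether a fluoro or a methoxy group in the same place would give a number like that of compound 3 or like that of compound 4. They also leave open how the change from chloro to hydroxy would behave on a core with an amine or a longer chain in place of the carboxylic acid.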